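Methoxy added to the dimethoxyphenyl of compound 3

The source may hold more compounds than are shown below. What is called first, only, known or untested is meant among the compounds shown, and "the series" means these compounds.

Compound 3 `COc1ccc(C2CC(c3cc(Cl)c(C)cc3O)=NN2c2ccc(S(N)(=O)=O)cc2)cc1OC` gives 28800 nM in a functional assay on IGROV-1 cells (Homo sapiens) for antiproliferative activity, with a stated time of 48 h; a lower number here means that less compound is tolerated, a higher number that more compound is tolerated. Compound 1 `Cc1cc(O)c(C2=NN(c3ccc(S(N)(=O)=O)cc3)C(c3ccccc3O)C2)cc1Cl` gives 37400 nM, which lies within the scatter of compound 3 (a 1.3-fold lower number from compound 1 to compound 3 (0.11 log units; within the scatter)). Compound 2 `Cc1cc(O)c(C2=NN(c3ccc(S(N)(=O)=O)cc3)C(/C=C/c3ccccc3)C2)cc1Cl` gives 68700 nM; the step of a 2.4-fold lower number from compound 2 to compound 3 (0.38 log units; beyond the scatter) is beyond the scatter, and a 1.8-fold higher number from compound 1 to compound 2 (0.26 log units; within the scatter) is not. Compound 4 `COc1ccc(C2CC(c3cc(Cl)c(C)cc3O)=NN2c2ccc(S(N)(=O)=O)cc2)c(OC)c1OC` differs from compound 3 by methoxy in place of hydrogen on an aromatic carbon. Among the measured compounds shown here, no measured step adds a methoxy on an aromatic carbon; the steps that touch the same ring position (a 1.3-fold lower number from compound 1 to compound 3 (0.11 log units; within the scatter), a 2.4-fold lower number from compound 2 to compound 3 (0.38 log units; beyond the scatter)) swap the whole aryl group and stay small. The expected step of a 1.0-fold higher number from compound 3 to compound 4 (0.02 log units; within the scatter) is therefore within the scatter, with no direction favoured. Compound 4 is estimated at 30000 nM in this assay, between 11000 nM and 80000 nM.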

Compound 4, concentration lethal to 50% of the cells: 26800 nM
Compound 4: middle estimate off by 1.1-fold (0.05 log units), on the high side, within the range that was stated.
By their numbers in this assay, from the lowest: compounds 4, 3, 1 and 2 (each within the scatter of the next, the first and the last beyond it).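

In this assay, adding a methoxy ortho to a large group on this ring stays within the scatter: a 1.1-fold lower number from compound 3 to compound 4 (0.03 log units; within the scatter). The 2,3,4-trimethoxyphenyl group keeps the gap to the 2-phenylethenyl group, a 2.6-fold lower number from compound 2 to compound 4 (0.41 log units; beyond the scatter), and stays within the scatter of the 2-hydroxyphenyl group, a 1.4-fold lower number from compound 1 to compound 4 (0.14 log units; within the scatter), as the 3,4-dimethoxyphenyl group did. No measurement shown explains this result.

Open, as far as these compounds go, is whether an amine, a carboxylic acid or a longer chain at this position would move the number beyond the scatter.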